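The compounds below may be only part of what the source reports. "The series", "measured", "known", "first", "only" and "open" are said of these compounds alone.

Among the compounds with values here, compound 3 `COc1ccc(N2CCN(C(=S)SCc3ccc(C(=O)Nc4ccccc4N)cc3)CC2)cc1` in a functional assay on A-375 cells (Homo sapiens) for antiproliferative activity, read by CCK-8 assay, with a stated time of 72 h, tested at 8 uM (on this read-out lower numbers stand for a weaker effect and higher numbers for a stronger effect at the one concentration tested), gives 35.9%, the second highest of the three numbers so far. Nearest to it is compound 1 `Nc1ccccc1NC(=O)c1ccc(CSC(=S)N2CCN(c3ccc(Cl)cc3)CC2)cc1`, which in this assay gives 29%; the gap between them is within the scatter. Furthest is compound 2 `CN(C(=S)SCc1ccc(C(=O)Nc2ccccc2N)cc1)c1cccnc1`, which in this assay gives 87.7%, a gap beyond the scatter.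

Within the data shown here, only one step between measured compounds lies at the same position on the aryl ring of the piperazine: a number 6.9 percentage points higher from compound 1 to compound 3 (within the scatter), a change within the scatter.

Compound 4 `Cc1ccc(N2CCN(C(=S)SCc3ccc(C(=O)Nc4ccccc4N)cc3)CC2)cc1` differs from compound 3 by methyl in place of methoxy on an aromatic carbon. Among the measured compounds shown here, no measured pair shows methyl in place of methoxy, so the expectation rests on the chloro-to-methoxy step alone, which was small; a further small change at the same aromatic carbon is therefore expected to give a step within the scatter in this assay, with no clear direction.

Compound 4 is estimated in this assay at 34%, with a range from 20% to 50%. This estimate means a step of a number 1.9 percentage points lower from compound 3 to compound 4 (within the scatter).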

Compound 4, a percentage reported as inhibition, at one concentration (the size of the read-out at that concentration, not a potency): 26.4%
Compound 4: middle estimate off by 7.6 percentage points, on the high side; low and high end bracket the measured number.
By their numbers in this assay, from the lowest: compounds 4, 1 and 3 (each within the scatter of the next); then compound 2.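

At the aromatic carbon para to a large group, methyl in place of methoxy gives a step in this assay (a number 9.5 percentage points lower from compound 3 to compound 4 (within the scatter)), and methyl in place of chloro gives another (a number 2.6 percentage points lower from compound 1 to compound 4 (within the scatter)). With three groups now read at this one carbon, methoxy, chloro and methyl all lie within the scatter of one another, so this small set of exchanges does not separate them on this read-out. No measurement offered here accounts for these steps.

Going by these compounds, it remains open whether a group of another kind at this carbon, such as an amine or a carboxylic acid, would give a step beyond the scatter. Compound 2 differs from these compounds in more than one place, so its value cannot be tied to this carbon.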